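A few compounds are considered here, and "the series" means these few. Any claim that something is new, unique, unknown or untested is made for them only; others in the source may bear on it.

In a functional assay on MES-SA cells (Homo sapiens) for inhibition, read by fluorescence, with a stated time of 72 h (on this read-out higher numbers stand for weaker inhibition and lower numbers for stronger inhibition), compound 1 (`FC(F)(F)c1ccccc1NC(=S)N/N=C/c1ccccn1`) gives 120 nM; 130 nM (2 entries) and compound 2 (`Oc1ccccc1/C=N/NC(=S)Nc1ccccc1`) gives 11500 nM; 14000 nM (2 entries). Compound 3 (`COc1ccc(NC(=S)N/N=C/c2ccccc2O)cc1`) gives 2670 nM, a value that falls between those two, and its two further entries provide no single number. Compound 4 (`Cc1ccc(NC(=S)N/N=C/c2ccccc2O)cc1`) differs from compound 3 at one place, with methyl in place of methoxy on an aromatic carbon, para to a large group: methyl in place of methoxy on an aromatic carbon. Within the data shown here, no measured step in this assay isolates this change, so the expectation rests on compound 3 at 2670 nM. The expected change is none beyond the scatter, and the estimated step is a 1.3-fold higher number from compound 3 to compound 4 (0.12 log units; within the scatter). For compound 4 the estimate is 3500 nM, with an expected range from 1400 nM to 8000 nM.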

Compound 4, half-maximal inhibitory concentration: 1440 nM
Compound 4: the middle estimate sits 2.4-fold (0.39 log units) above what was measured; measured number inside the range.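

In this assay, among these compounds, the swap of methoxy for methyl on an aromatic carbon, para to a large group, gives a 1.9-fold lower number from compound 3 to compound 4 (0.27 log units; within the scatter) and is the first single-place change measured here. This position therefore accepts methyl as well as methoxy, and losing one hydrogen-bond acceptor and one heavy atom produces no shift beyond the scatter. Nothing measured here bears on why the step has this size.

As far as these compounds go, it remains open whether an amine or a carboxylic acid at this position would move the number beyond the scatter. From the compounds shown here alone, it is also open whether the same swap would behave alike on the core of compound 1.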